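From Methyl to Fluoro on Compound 1

A few compounds are considered here, and "the series" means these few. Any claim that something is new, unique, unknown or untested is made for them only; others in the source may bear on it.

In an ADME assay on HEK-293T cells (Homo sapiens) for cytotoxicity, read by MTT assay, with a stated time of 24 h (on this read-out higher numbers stand for lower toxicity in this test and lower numbers for higher toxicity in this test), compound 1 `Cc1ccc(-c2nn(-c3ccccc3)cc2-c2nc3ccccc3n2S(=O)(=O)c2ccc(F)cc2)cc1` gives 128000 nM, compound 2 `Cc1ccc(-c2nn(-c3ccccc3)cc2-c2nc3ccccc3n2S(=O)(=O)c2ccc(Br)cc2)cc1` gives 159000 nM and compound 3 `Cc1ccc(-c2nn(-c3ccccc3)cc2-c2nc3ccccc3n2S(=O)(=O)c2ccc(C(F)(F)F)cc2)cc1` gives 182000 nM. These values lie within the scatter of one another, so compound 1 stands level with the other two. Compound 4 `O=S(=O)(c1ccc(F)cc1)n1c(-c2cn(-c3ccccc3)nc2-c2ccc(F)cc2)nc2ccccc21` differs from compound 1 in one place: fluoro in place of methyl on an aromatic carbon, with 4-methylphenyl becoming 4-fluorophenyl. Within the data shown here, no measured step makes this exact swap. The closest steps exchange other groups on an aromatic carbon: a 1.2-fold higher number from compound 1 to compound 2 (0.09 log units; within the scatter), a 1.4-fold higher number from compound 1 to compound 3 (0.15 log units; within the scatter) and a 1.1-fold higher number from compound 2 to compound 3 (0.06 log units; within the scatter), each within the scatter. No shift beyond the scatter is therefore expected in this assay. The expected size of the change is a 1.1-fold higher number from compound 1 to compound 4 (0.04 log units; within the scatter). For compound 4, the estimate is 140000 nM, within an expected range of 80000 nM to 250000 nM.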

Compound 4, half-maximal cytotoxic concentration: 218000 nM
Estimate against measurement, compound 4: 1.6-fold (0.19 log units) below; the measured number falls inside the stated range.
By their numbers in this assay, from the lowest: compounds 1, 2, 3 and 4 (each within the scatter of the next).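

Replacing 4-methylphenyl with 4-fluorophenyl gives, in this assay, a 1.7-fold higher number from compound 1 to compound 4 (0.23 log units; within the scatter). Among these compounds, the earlier steps all changed a group on a different aromatic ring, so this is the first evidence that a swap at this second position also stays within the scatter. The data offer no explanation for the size of this step.

The compounds shown leave open whether an amine, a carboxylic acid or a longer chain in place of the methyl would move the number beyond the scatter. With only methyl and fluoro compared here, no trend can be drawn for this position.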